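Cyclohexyl benzimidazole amides: Vero cytotoxicity, methyl for tert-butyl

The source may report more compounds than this note shows. Statements on the series, on what has been measured and on what is new or still open speak of the compounds shown alone.

Three compounds of the series have entries in an ADME assay on Vero cells (Chlorocebus sabaeus) for cytotoxicity, read by resazurin assay, with a stated time of 3 days; on this read-out higher numbers stand for weaker inhibition and lower numbers for stronger inhibition. For compound 1 `CCN(CC)c1cc2[nH]c(C3CCCCC3)nc2cc1NC(=O)c1ccc(N(C)C)cc1` the entry reads "not determined" (no result reported). Compound 2 `O=C(CCc1ccccc1)Nc1cc2nc(C3CCCCC3)[nH]c2cc1N1CCCC1` gives > 100 ug/mL, which is a limit of this assay rather than a number. Compound 3 `CN(C)c1cc2[nH]c(C3CCCCC3)nc2cc1NC(=O)c1ccc(C(C)(C)C)cc1` likewise gives > 100 ug/mL, again a limit of this assay. So compound 3 stands at the same limit as compound 2, with no number to rank either against the other.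

Compound 4 `Cc1ccc(C(=O)Nc2cc3nc(C4CCCCC4)[nH]c3cc2N(C)C)cc1` is the next one to be tested in this assay. It differs from compound 3 by methyl in place of tert-butyl on an aromatic carbon. With both measured neighbours at the limit, the step from compound 3 to compound 4 is expected to be a number no higher from compound 3 to compound 4 (the limit leaves the size open), none beyond the scatter. Compound 4 is accordingly estimated at 100 ug/mL, within 50 ug/mL to 200 ug/mL, most likely reported again only as a limit.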

Compound 4, half-maximal inhibitory concentration: > 100 ug/mL
Compound 4 gave a limit, no number (the forecaster's own chance of this, stated with the estimate: 80%); the middle value lies on the limit itself.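

No step can be read from compound 3 to compound 4, since both entries are limits and not numbers: the limit of > 100 ug/mL in this assay, at which 3 of the 4 values shown sit.

The compounds shown leave open whether methyl and tert-butyl differ at all in this assay, as none gives a number there.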